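The source may report more compounds than this note shows. Statements on the series, on what has been measured and on what is new or still open speak of the compounds shown alone.

Measured in a functional assay on T-24 cells (Homo sapiens) for cytotoxicity, read by MTT assay, with stated times of 48 h and 4 h; a lower number here means a stronger inhibitor, a higher number a weaker inhibitor:

compound 1 `COc1ccc(/C=C/c2nc(NCCN3CCCCC3)c3ccccc3n2)cc1OC` gives 10500 nM
compound 2 `COc1ccc(/C=C/c2nc(NCCCCN)c3ccccc3n2)cc1OC` gives 30900 nM
compound 3 `COc1ccc(/C=C/c2nc(NCCN(C(C)C)C(C)C)c3cc(Cl)ccc3n2)cc1OC` gives 14900 nM

Compound 2 has the highest number of the three, and compound 3 stands nearest to it. Compound 4 `COc1ccc(/C=C/c2nc(NCCCCN)c3cc(Cl)ccc3n2)cc1OC` is compound 2 with chloro in place of hydrogen on an aromatic carbon. Going by the values given here, no measured step covers this change. Among the compounds with values here, the only measured step, a 2.9-fold higher number from compound 1 to compound 2 (0.47 log units; beyond the scatter), lies in the chain and not at this place, so it bears on the change only weakly. Compound 3 carries chloro, but on a different chain and without a measured partner lacking it. No step beyond the scatter is therefore expected in this assay, at most a slightly lower number. The expected step is a 1.5-fold lower number from compound 2 to compound 4 (0.17 log units; within the scatter). Compound 4 is estimated at 21000 nM, with an expected range of 10000 nM to 42000 nM.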

Compound 4, half-maximal inhibitory concentration: 7820 nM
Beside the measured number, compound 4's estimate is 2.7-fold (0.43 log units) above it; the whole stated range lies above it.
By their numbers in this assay, from the lowest: compounds 4, 1 and 3 (each within the scatter of the next); then compound 2.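

In this assay, chloro in place of hydrogen on an aromatic carbon, meta to a fused ring and para to a fused ring, gives a 4.0-fold lower number from compound 2 to compound 4 (0.60 log units; beyond the scatter), so this position responds to the change by more than the scatter. With chloro present on both compounds, 2-aminoethyl in place of diisopropylamino on the chain gives a 1.9-fold lower number from compound 3 to compound 4 (0.28 log units; within the scatter), a step that stays within the scatter. Nothing measured here accounts for the step at this position. From the compounds shown here alone, whether fluoro, bromo or methoxy on the same carbon would give a similar step remains open. So does the effect of chloro alongside the piperidin-1-yl chain.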